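Chloro for Hydrogen on the Benzylidene Ring

This account rests on a few compounds, and the source may have more. Where it says the series, first, only, none or still open, it means among the compounds named here.

Measured compounds:
compound 1, `Cc1ccc2c(c1)C(=O)/C(=C/c1ccccc1)CN2CC(=O)O`: 4.23%
compound 2, `Cc1cc(C)cc(/C=C2\CN(CC(=O)O)c3c(C)cccc3C2=O)c1`: 17.5%

Both compounds share one core and were tested in an assay on HL-60 cells for inhibition of glutathione S-transferase P (Homo sapiens), read by spectrophotometry, tested at 20 uM; on this read-out lower numbers stand for less inhibition and higher numbers for more inhibition at the one concentration tested (going by the name of the read-out). Compound 1 gives 4.23%, the lower of the two numbers. Compound 2, which carries two methyl groups on its pendant ring and a further methyl on the core, gives 17.5%; the gap between compound 2 and compound 1 goes beyond the usual scatter, so compound 1 stands clearly at the bottom of what has been measured so far. Within the data shown here, no pair of measured compounds differs in only one place, so no single change has yet been tied to a step in this assay.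

Compound 3, `Cc1ccc2c(c1)C(=O)/C(=C/c1ccc(Cl)cc1)CN2CC(=O)O`, has not been measured. It differs from compound 1 in a single place: chloro in place of hydrogen on an aromatic carbon. Among the measured compounds shown here, with no measured step to lean on, only a modest shift is expected, in the upward direction if any; the step is estimated as a number 5.8 percentage points higher from compound 1 to compound 3 (within the scatter), which may not exceed the scatter. Compound 3 is therefore expected to give about 10% in this assay, with a range from 0% to 25%.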

Compound 3, a percentage reported as inhibition, at one concentration (the size of the read-out at that concentration, not a potency): 20.7%
The estimate for compound 3 lay 10.7 percentage points below the measured number; low and high end bracket the measured number.
By their numbers in this assay, from the lowest: compound 1; then compounds 2 and 3 (each within the scatter of the next).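

Among these compounds, the change from phenyl to 4-chlorophenyl is the first single change that can be tied to a step in this assay, and it reads a number 16.5 percentage points higher from compound 1 to compound 3 (beyond the scatter) on the shared core. This marks the aromatic carbon para to a large group as a place where one chlorine atom, with the rest of compound 1 left as it stands, moves the number beyond the usual scatter. Compounds 1 and 2 differ in more than one place, so they could not show this for any single position.

What a fluoro, a methoxy or an amine group would do on this same carbon stays open, so the compounds shown cannot say whether the step is particular to chloro or would come with other groups there. Also open, as far as these compounds go, is whether chloro on another carbon of that ring would give a step of like size, and whether this step would carry over to a compound with the added methyl groups of compound 2. Nothing measured here bears on why the number moves with this change.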